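Series notes: replacing the aryl group on the shared core

A few compounds are considered here, and "the series" means these few. Any claim that something is new, unique, unknown or untested is made for them only; others in the source may bear on it.

Measured so far:
compound 1 `O=C(O)Cc1sc(C(c2ccccc2)c2ccc(Cl)cc2)nc1-c1ccc(Cl)cc1`: 75 nM
compound 2 `O=C(O)Cc1sc(C(c2ccc(F)cc2)c2ccc(F)cc2)nc1-c1ccoc1`: 130 nM

In an in vitro functional assay on HEK285-7 cells for antagonist activity at prostaglandin D2 receptor 2 (Homo sapiens), read by BRET and beta-arrestin recruitment (on this read-out higher numbers stand for weaker inhibition and lower numbers for stronger inhibition), compound 1 gives 75 nM and compound 2 gives 130 nM. Compound 2 stands with the higher of the two numbers, yet its gap to compound 1 lies within the scatter, so the two values show no order between them. Among the compounds with values here, no pair of measured compounds differs in only one place, so no measured step is available in this set.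

Compound 3 `Nc1cc(-c2nc(C(c3ccc(F)cc3)c3ccc(F)cc3)sc2CC(=O)O)cc(F)n1` keeps the rest of compound 2 and carries one change: 2-amino-6-fluoropyridin-4-yl in place of furan-3-yl on an aromatic carbon. This kind of change has not been measured in the series. The two groups seen so far at this place, in compound 1 and compound 2, give numbers within the scatter of each other, which gives no ground for a large move in either direction. The expected step, a 1.3-fold lower number from compound 2 to compound 3 (0.11 log units; within the scatter), is therefore estimated to stay within the scatter. Compound 3 is estimated at 100 nM, with a range from 35 nM to 300 nM.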

Compound 3, half-maximal inhibitory concentration: 1400 nM
The estimate for compound 3 lay 14-fold (1.15 log units) below the measured number; measured number above the stated range.
By their numbers in this assay, from the lowest: compounds 1 and 2 (each within the scatter of the next); then compound 3.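

In this assay, 2-amino-6-fluoropyridin-4-yl in place of furan-3-yl gives an 11-fold higher number from compound 2 to compound 3 (1.03 log units; beyond the scatter) on the otherwise unchanged structure. Within the data shown here, this is the only one-place step so far, and it shows that the group on this aromatic carbon, next to the ring nitrogen, can move the number well beyond the scatter. Compound 1 and compound 2 could not show this, as they differ in more than one place, and no evidence on hand accounts for the size of the step.

The entering group differs from furan-3-yl in its six-membered ring, its amino group and its fluorine at once, and the compounds shown do not separate these three. Plain pyridin-4-yl, or its 2-amino or 2-fluoro form alone, would leave the same question open until read in this setting.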